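The compounds below may be only part of what the source reports. "The series", "measured", "known", "first", "only" and "open" are said of these compounds alone.

In an ADME assay on MT4 cells (Homo sapiens) for cytotoxicity, read by MTT assay, with a stated time of 5 days (a higher number here means that more compound is tolerated, a lower number that less compound is tolerated), compound 1 `Cc1cc(C)cc(S(=O)(=O)c2c(C(=O)N[C@@H]3CCN(CC(N)=O)C3)[nH]c3ccc(Cl)cc23)c1` gives 31000 nM and compound 2 `Cc1cc(C)cc(S(=O)(=O)c2c(C(=O)NC3CN(Cc4cccnc4)C3)[nH]c3ccc(Cl)cc23)c1` gives 36000 nM, and the step between them, a 1.2-fold higher number from compound 1 to compound 2 (0.06 log units; within the scatter), changes nothing measurable. Compound 3 `Cc1cc(C)cc(S(=O)(=O)c2c(C(=O)NC3CN(Cc4ccccc4F)C3)[nH]c3ccc(Cl)cc23)c1` reads > 238000 nM, which is a limit of the assay and not a number; the limit of > 238000 nM in this assay, at which 1 of the 3 values shown sits, is the only such entry in the set. Its true position is therefore open on the upper side, and it stands apart from the other two.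

The next structure is compound 4 `Cc1cc(C)cc(S(=O)(=O)c2c(C(=O)NS(=O)(=O)C3CC3)[nH]c3ccc(Cl)cc23)c1`, with cyclopropylsulfonyl in place of 1-(2-fluorobenzyl)azetidin-3-yl on an amide-type nitrogen. Among the measured compounds shown here, two measured steps bear on this site, an at least 7.6-fold higher number from compound 1 to compound 3 (0.88 log units; beyond the scatter) and an at least 6.6-fold higher number from compound 2 to compound 3 (0.82 log units; beyond the scatter). Both end at compound 3, and both are beyond the scatter. Neither involves cyclopropylsulfonyl, so they only show that the group now leaving goes with the highest reading so far. With that group gone, a return toward the level of compound 1 at 31000 nM and compound 2 at 36000 nM is expected, though not necessarily all the way. A move to a lower number is therefore expected, an estimated at least 3.9-fold lower number from compound 3 to compound 4 (0.59 log units; beyond the scatter). For compound 4 the estimated value is 60000 nM, with an expected range of 15000 nM to 240000 nM.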

Compound 4, half-maximal cytotoxic concentration: 147000 nM
Compound 4: the middle estimate sits 2.5-fold (0.39 log units) below what was measured, within the range that was stated.
By their numbers in this assay, from the lowest: compounds 1 and 2 (each within the scatter of the next); then compound 4. At a limit, above all of these: compound 3.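

On the amide-type nitrogen, cyclopropylsulfonyl is the first group shown with no ring nitrogen, and in this assay it separates clearly from the two lower compounds: a 4.1-fold higher number from compound 2 to compound 4 (0.61 log units; beyond the scatter) and a 4.7-fold higher number from compound 1 to compound 4 (0.68 log units; beyond the scatter); a high reading at this place is therefore not confined to 1-(2-fluorobenzyl)azetidin-3-yl, and it does not simply follow from an azetidine ring, since compound 2 carries one and reads low. As far as these compounds go, the step of an at least 1.6-fold lower number from compound 3 to compound 4 (0.20 log units; that floor lies within the scatter) gives only a floor, so its true size remains open. Compound 3 remains a limit of the assay and not a number: the limit of > 238000 nM in this assay, at which 1 of the 4 values shown sits.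

The compounds shown do not separate the contribution of the sulfonyl from that of the cyclopropyl ring, so it remains open whether methylsulfonyl or phenylsulfonyl on the same nitrogen, or a cyclopropyl group bound there directly, would keep a reading like that of compound 4. From the compounds shown here alone, it also remains open whether the 2-fluorobenzyl group would give a high reading on a pyrrolidine ring, as this group appears only on the azetidine of compound 3.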